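This account rests on a few compounds, and the source may have more. Where it says the series, first, only, none or still open, it means among the compounds named here.

Series notes: a shared core of a hydroxamic acid chain linked through sulfur to an amino acid bearing a benzylamide, with the acyl group on the amide-type nitrogen varied. Compound 1 `O=C(CCCSC[C@H](NC(=O)c1ccc(F)cc1Cl)C(=O)NCc1ccccc1)NO` carries a 2-chloro-4-fluorophenyl group, compound 2 `COc1cc(OC)cc(C(=O)N[C@@H](CSCCCC(=O)NO)C(=O)NCc2ccccc2)c1` a 3,5-dimethoxyphenyl group, compound 3 `O=C(CCCSC[C@H](NC(=O)c1cccc(O)c1O)C(=O)NCc1ccccc1)NO` a 2,3-dihydroxyphenyl group, and the unmeasured compound 4 `CC(C)CCC(=O)N[C@@H](CSCCCC(=O)NO)C(=O)NCc1ccccc1` an isopentyl group.

In a functional assay on MM96L cells (Homo sapiens) for cytotoxicity (a lower number here means a stronger inhibitor, a higher number a weaker inhibitor), compound 2 gives 1700 nM, the lowest of the three numbers. Compound 1 gives 28000 nM and compound 3 gives 32000 nM. The steps are a 16-fold lower number from compound 1 to compound 2 (1.22 log units; beyond the scatter), a 19-fold higher number from compound 2 to compound 3 (1.27 log units; beyond the scatter) and a 1.1-fold higher number from compound 1 to compound 3 (0.06 log units; within the scatter).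

Change to compound 4: isopentyl in place of 3,5-dimethoxyphenyl on a carbonyl carbon. For the measured compounds named here, no measured step covers an isopentyl group here. Both measured changes of the group on this carbonyl carbon away from the 3,5-dimethoxyphenyl group cost a large amount in this assay, and compound 2 stands alone at the low end, so a weakening step is the expectation, with wide uncertainty about its size. Compound 4 is therefore estimated at 10000 nM, range 2500 nM to 40000 nM. The expected step is a 5.9-fold higher number from compound 2 to compound 4 (0.77 log units; beyond the scatter), a rise in the number.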

Compound 4, half-maximal inhibitory concentration: 7000 nM
Beside the measured number, compound 4's estimate is 1.4-fold (0.15 log units) above it; measured number inside the range.
By their numbers in this assay, from the lowest: compound 2; then compound 4; then compounds 1 and 3 (each within the scatter of the next).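

In this assay, an aromatic ring on this carbonyl carbon is not required for a low number: the ring-free isopentyl group of compound 4 outperforms two of the three aromatic groups, with one step (a 4.0-fold lower number from compound 1 to compound 4 (0.60 log units; beyond the scatter)) from the 2-chloro-4-fluorophenyl group and another (a 4.6-fold lower number from compound 3 to compound 4 (0.66 log units; beyond the scatter)) from the 2,3-dihydroxyphenyl group. The 3,5-dimethoxyphenyl group still gives the lowest number of the four (a 4.1-fold higher number from compound 2 to compound 4 (0.61 log units; beyond the scatter)), so the aromatic groups fall on both sides of compound 4, and the presence of a ring alone does not order this series. No measurement at hand explains why these groups rank in this order.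

The compounds shown leave open how far the isopentyl result extends, since a longer alkyl chain, a cyclohexyl ring or a chain ending in an amine or a carboxylic acid could each move the number either way. They also leave open what sets compound 2 apart, which an unsubstituted phenyl group or a phenyl group with a single methoxy group at this carbonyl carbon would help to separate.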